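This account rests on a few compounds, and the source may have more. Where it says the series, first, only, none or still open, it means among the compounds named here.

Working notes on the series. Compound 2 `Cc1cc(C)cc(Cc2ccc3c(NCCCNCc4ccco4)ccnc3c2)c1` gives 23 10^-6 cm/s in an ADME assay for permeability, using PAMPA, with a stated time of 30 min, at pH 7.4 (on this read-out lower numbers stand for lower permeability and higher numbers for higher permeability), the lowest of the three numbers measured; compound 1 `COc1ccccc1Oc1ccc2c(NCCCNCc3ccco3)ccnc2c1` gives 317 10^-6 cm/s and compound 3 `c1coc(CNCCCNc2ccnc3cc(-c4cccc5ccccc45)ccc23)c1` gives 237 10^-6 cm/s, with a 14-fold lower number from compound 1 to compound 2 (1.14 log units; beyond the scatter) and a 10-fold higher number from compound 2 to compound 3 (1.01 log units; beyond the scatter), while a 1.3-fold lower number from compound 1 to compound 3 (0.13 log units; within the scatter). Compound 4 `FC(F)(F)c1cccc(Cc2ccc3c(NCCCNCc4ccco4)ccnc3c2)c1` is not yet measured in this assay. It differs from compound 2 by 3-(trifluoromethyl)phenyl in place of 3,5-dimethylphenyl on a saturated chain carbon bound to an aromatic carbon. Going by the values given here, no measured step alters the group on the saturated chain carbon; the two large steps that touch compound 2 each replace the whole group on the aromatic carbon, and the sole step that keeps an aromatic carbon substituent of similar type stays within the scatter. No step beyond the scatter is therefore expected for compound 4 in this assay, as a 1.3-fold higher number from compound 2 to compound 4 (0.12 log units; within the scatter). The estimate for compound 4 is 30 10^-6 cm/s, within 10 10^-6 cm/s to 90 10^-6 cm/s.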

Compound 4, apparent permeability: 23 10^-6 cm/s
Compound 4: middle estimate off by 1.3-fold (0.12 log units), on the high side; the measured number falls inside the stated range.
By their numbers in this assay, from the lowest: compounds 2 and 4 (each within the scatter of the next); then compounds 3 and 1 (each within the scatter of the next).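

In this assay, going by these compounds alone, this is the first change at the saturated chain carbon bound to an aromatic carbon: 3-(trifluoromethyl)phenyl in place of 3,5-dimethylphenyl gives no change at the digits printed from compound 2 to compound 4 (within the scatter). This exchange of one substituted phenyl for another therefore does not produce a large step like those seen when the whole group on the aromatic carbon of compound 2 is replaced. Nothing available explains why the two groups give the same number.

Still open, on these data alone, is whether a pyridine ring on the same carbon would shift the number. Also open, as far as these compounds go, is whether a phenyl carrying a carboxylic acid or an amine would do so.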